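The source may hold more compounds than are shown below. What is called first, only, known or untested is meant among the compounds shown, and "the series" means these compounds.

Within the data shown here, in a functional assay on HCC827 cells (Homo sapiens) for inhibition, read by fluorescence, with a stated time of 72 h (on this read-out higher numbers stand for weaker inhibition of growth and lower numbers for stronger inhibition of growth), two compounds have numbers so far. Compound 1 `CC(C)CCn1cnc2c(Nc3ccc(Cl)cc3)nc(N[C@H]3CC[C@H](N)CC3)nc21` gives 10200 nM, and compound 2 `N[C@H]1CC[C@H](Nc2nc(Nc3ccc(O)cc3)c3ncn(C4CCCCC4)c3n2)CC1` gives 32500 nM. That is the higher of the two numbers and the gap lies beyond the usual scatter, so compound 2 is the weaker growth inhibitor of this pair. Compound 3 `CC(C)CCn1cnc2c(Nc3ccc(O)cc3)nc(N[C@H]3CC[C@H](N)CC3)nc21` has not been measured yet. It is compound 2 with one change: isopentyl in place of cyclohexyl on an aromatic nitrogen. Among the measured compounds shown here, no pair of measured compounds differs in one place only, so nothing yet shows what this swap does alone. A modest step towards a lower number is expected, possibly not beyond the scatter, and the only hint of direction is compound 1 at 10200 nM. The estimated step is a 1.6-fold lower number from compound 2 to compound 3 (0.21 log units; within the scatter). For compound 3 the estimated value is 20000 nM, with an expected range of 8000 nM to 45000 nM.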

Compound 3, concentration for 50% growth inhibition: 14400 nM
Estimate against measurement, compound 3: 1.4-fold (0.14 log units) above; the measured number falls inside the stated range.
By their numbers in this assay, from the lowest: compounds 1 and 3 (each within the scatter of the next); then compound 2.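

Replacing cyclohexyl with isopentyl on the aromatic nitrogen gives a 2.3-fold lower number from compound 2 to compound 3 (0.35 log units; beyond the scatter) in this assay, the first direct sign that the group at this position affects growth inhibition, although the effect is modest. Hydroxy in place of chloro on an aromatic carbon gives a 1.4-fold higher number from compound 1 to compound 3 (0.15 log units; within the scatter), so this swap produces no clear change in the read-out. No supporting measurement explains why the isopentyl swap shifts the number.

The isopentyl result rests on a single pair with hydroxy on the aromatic carbon, so it remains unclear whether the same swap would give a similar step with chloro there. On these data alone, the effect of other groups on the aromatic nitrogen, such as ethyl or a longer chain ending in an amine, also remains open.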